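Swapping One Side Group on Compound 1

The source may report more compounds than this note shows. Statements on the series, on what has been measured and on what is new or still open speak of the compounds shown alone.

In a functional assay on RCC4 cells (Homo sapiens) for inhibition, read by XTT assay, with a stated time of 4 days (on this read-out higher numbers stand for weaker inhibition and lower numbers for stronger inhibition), compound 1 `COC(=O)C=CC(=O)c1sc(Nc2cccc(C)c2)nc1-c1ccncc1` gives 2510 nM, a single measurement. Two related compounds were each measured twice, and their repeat entries agree closely. Compound 3 `Cc1cccc(Nc2nc(-c3ccncc3N3CCN(C)CC3)cs2)c1` gives 2600 nM; 2630 nM (2 entries), which lies within the usual scatter of the value for compound 1. Compound 2 `Cc1cccc(Nc2nc(-c3ccnc(-c4ccsc4)c3)cs2)c1` gives 8700 nM; 8710 nM (2 entries), a clearly higher number and so weaker inhibition. Compound 1 therefore sits at the stronger end of this small set, level with compound 3.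

The next molecule is compound 4 `Cc1cccc(Nc2nc(-c3ccncc3)c(CN3CCCCC3)s2)c1`, which has not yet been measured. It differs from compound 1 in one place: (piperidin-1-yl)methyl in place of (2-(methoxycarbonyl)ethenyl)carbonyl on an aromatic carbon. Put simply, (piperidin-1-yl)methyl stands in place of (2-(methoxycarbonyl)ethenyl)carbonyl on an aromatic carbon, next to the ring sulfur.

Among the measured compounds shown here, no measured pair in this set differs in only one place, so no direct precedent fixes the size of this change. For the measured compounds named here, the only guide is the spread of the three measured compounds, the highest number coming from compound 2, which gives 8700 nM; 8710 nM (2 entries). In this assay, no step beyond the scatter is expected, though with real uncertainty toward weaker inhibition. The expected change is a 1.2-fold higher number from compound 1 to compound 4 (0.08 log units; within the scatter). For compound 4, the estimated value is 3000 nM, with an expected range of 800 nM to 12000 nM.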

Compound 4, half-maximal inhibitory concentration: 13200 nM
Compound 4: middle estimate off by 4.4-fold (0.64 log units), on the low side; the whole stated range lies below it.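

In this assay, (piperidin-1-yl)methyl in place of (2-(methoxycarbonyl)ethenyl)carbonyl, on the aromatic carbon next to the ring sulfur, gives a 5.3-fold higher number from compound 1 to compound 4 (0.72 log units; beyond the scatter), which means weaker inhibition. This is the only pair shown that differs in one place, so it gives the first direct sign that the group on this carbon can change the read-out and that this particular swap costs inhibition rather than leaving it level. Repeat entries in this assay agree closely, which supports reading a step of this size as a real difference rather than noise: the several entries of compound 2 in this assay, 8700 nM; 8710 nM (2 entries)

The swap changes several things at once, since the group that leaves has no ring and three double bonds, while the group that enters has a six-membered non-aromatic ring and a nitrogen, so this single pair cannot show which of these differences matters. Still open, on these data alone, is how a small group such as acetyl, a carboxylic acid at the end of the ethenyl chain, or a simple amine such as dimethylaminomethyl on the same carbon would compare with compound 1.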